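From 4-fluorophenyl to (pyridin-4-yl)methyl on the shared core

This account rests on a few compounds, and the source may have more. Where it says the series, first, only, none or still open, it means among the compounds named here.

- compound 1 (`Cc1cc(Nc2nn(-c3ccc(F)cc3)c(=O)c3ccccc23)n[nH]1`) gives 1600 nM
- compound 2 (`Cc1ccc(-n2nc(Nc3cc[nH]n3)c3ccccc3c2=O)cc1`) gives "not determined" (no result reported)

For the measured compounds named here, in a functional assay on MCF7 cells (Homo sapiens) for cytotoxicity (on this read-out lower numbers stand for stronger inhibition and higher numbers for weaker inhibition), compound 1 holds the only number available, so it cannot yet be ranked against anything, and compound 2 offers no result for comparison. Compound 3 (`Cc1cc(Nc2nn(Cc3ccncc3)c(=O)c3ccccc23)n[nH]1`) keeps the core of compound 1 but carries (pyridin-4-yl)methyl in place of 4-fluorophenyl on an aromatic nitrogen. Going by the values given here, no measured step between compounds differing in one place is available as a guide, so any forecast in this assay remains tentative. A modest shift towards weaker inhibition is expected, although a result within the usual scatter would not be surprising. The estimated step is a 1.9-fold higher number from compound 1 to compound 3 (0.27 log units; within the scatter) and it carries wide uncertainty. For compound 3 the expected value is 3000 nM with an estimated range from 800 nM to 12000 nM.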

Compound 3, half-maximal inhibitory concentration: > 30000 nM
Compound 3: only a limit was reported; the forecaster's own chance of this, stated with the estimate: 15%; middle value at least 10-fold (1.00 log units) away from the limit.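

On an aromatic nitrogen of the shared core, placing (pyridin-4-yl)methyl in place of 4-fluorophenyl in this assay gives an at least 18-fold higher number from compound 1 to compound 3 (1.27 log units; beyond the scatter), the first step available for this position. Compound 3 gives a limit of the assay and not a number: the limit of > 30000 nM in this assay, at which 1 of the 3 values shown sits. The step therefore shows that this position is sensitive in this assay, since one exchange here moves the read-out beyond the scatter, even though the entering and leaving groups have the same heavy-atom count.

As far as these compounds go, the true size of the step stays open, and so does which part of the exchange carries it, as the ring nitrogen, the methyl link and the loss of fluorine all change together. A plain benzyl group or a pyridin-4-yl ring placed directly on this nitrogen would begin to separate these parts.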